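This account rests on a few compounds, and the source may have more. Where it says the series, first, only, none or still open, it means among the compounds named here.

Compound 1 `Cn1ccnc1[C@@H](CC(=O)O)c1ccc(OCc2cccc(-c3ccccc3S(C)(=O)=O)c2)cc1` — "not determined" (no result reported)
Compound 2 `Cc1cc(Cl)ccc1-c1cccc(COc2ccc([C@H](CC(=O)O)c3nccn3C)cc2)c1C` — 23000 nM

Two compounds were measured in an assay on CHO cells for agonist activity at Free fatty acid receptor 1 (Homo sapiens), read by luminescence, with a stated time of 20 s, in the presence of a further agent that is not named here; on this read-out higher numbers stand for an effect only at larger amounts of compound and lower numbers for an effect already at smaller amounts. Compound 2 gives 23000 nM in this assay, a weak effect that needs a large amount of compound. Among the measured compounds shown here, for compound 1 no single number stands in this assay; the result is given as "not determined" (no result reported), so where compound 1 stands cannot be read from a value of its own, and no step from compound 1 to compound 2 can be counted.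

Compound 3 `Cn1ccnc1[C@@H](CC(=O)O)c1ccc(OCc2cccc(-c3ccc(Cl)cc3Cl)c2)cc1` differs from compound 1 in one place: 2,4-dichlorophenyl in place of 2-(methylsulfonyl)phenyl on an aromatic carbon. For the measured compounds named here, no measured step between two compounds exists here, so the size of this change in this assay cannot be anchored on a known pair; only compound 2, which carries chlorine on its terminal ring, offers a reference, and its value is weak. Compound 3 is therefore expected to sit in a similar weak range, estimated at 12000 nM, with a range from 2500 nM to 50000 nM.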

Compound 3, half-maximal effective concentration: 30000 nM
Beside the measured number, compound 3's estimate is 2.5-fold (0.40 log units) below it; the measured number falls inside the stated range.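

No new step can be read in this assay: for compound 1 the result stands as "not determined" (no result reported) and so its change to compound 3 cannot be sized. The compounds shown leave open what replacing 2-(methylsulfonyl)phenyl with 2,4-dichlorophenyl does to the read-out. Nothing shown bears on the reason for compound 3's result.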